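The source may hold more compounds than are shown below. What is called first, only, known or untested is meant among the compounds shown, and "the series" means these compounds.

Two members of the series carry a measured value in an assay on isolated protein for inhibition of Amine oxidase [flavin-containing] B (Homo sapiens), read by fluorescence and Amplex Red, with a stated time of 30 min, tested at 100 uM; on this read-out higher numbers stand for a stronger effect at the one concentration tested and lower numbers for a weaker effect. Compound 1 `COCCNc1nnc(SCC(=O)N(Cc2cccc([N+](=O)[O-])c2)c2ccc(F)cc2)s1` gives 25.7%. Compound 2 `C=CCNc1nnc(SCC(=O)N(Cc2cccc([N+](=O)[O-])c2)c2ccc(F)cc2)s1` gives 29.2%. Within the data shown here, the one measured step, a number 3.5 percentage points higher from compound 1 to compound 2 (within the scatter), falls within the scatter, so although compound 2 holds the higher of the two numbers on record, with compound 1 nearest, the two are not separated by this assay.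

Compound 3 `CC(C)Nc1nnc(SCC(=O)N(Cc2cccc([N+](=O)[O-])c2)c2ccc(F)cc2)s1` is the next member to be measured in this assay. It differs from compound 2 by isopropyl in place of allyl on a nitrogen on an aromatic ring. Among the measured compounds shown here, no measured step covers this exact exchange. For the measured compounds named here, the only step measured so far, a number 3.5 percentage points higher from compound 1 to compound 2 (within the scatter), changed a different group at the same nitrogen and stayed within the scatter, and both measured values lie in a narrow band. Nothing on record therefore points to a shift beyond the scatter for compound 3. The step expected for compound 3 is a number 2.2 percentage points lower from compound 2 to compound 3 (within the scatter), no more than the scatter in either direction. Compound 3 is accordingly estimated at 27%, with a range from 14% to 40%.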

Compound 3, a percentage reported as inhibition, at one concentration (the size of the read-out at that concentration, not a potency): 28.5%
Compound 3: middle estimate off by 1.5 percentage points, on the low side; measured number inside the range.
By their numbers in this assay, from the lowest: compounds 1, 3 and 2 (each within the scatter of the next).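

Working from this assay, the exchange of allyl for isopropyl on the nitrogen on the aromatic ring keeps the count of 3 carbons and removes the double bond outside aromatic rings, and it comes to a number 0.7 percentage points lower from compound 2 to compound 3 (within the scatter), so this read-out does not register that exchange. The exchange of 2-methoxyethyl for isopropyl at the same nitrogen comes to a number 2.8 percentage points higher from compound 1 to compound 3 (within the scatter), which means that all three measured pairs at this position now lie within the scatter and that allyl, isopropyl and 2-methoxyethyl cannot be ranked here. No supporting data bear on these results.

On these data alone, it remains open whether any group at this nitrogen moves the number beyond the scatter, for instance a cyclohexyl or benzyl group, a longer chain such as n-hexyl, or a chain ending in a carboxylic acid or an amine. The series shown also leaves open how the read-out responds to exchanges elsewhere on the shared core, such as replacing the nitro group or the fluorine.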